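Series notes: ethyl to propyl, compound 2 to compound 4

A few compounds are considered here, and "the series" means these few. Any claim that something is new, unique, unknown or untested is made for them only; others in the source may bear on it.

The series shares one core, varied at an aromatic carbon and along the chain. Compound 1 `CC[C@@H](CCn1cncn1)c1ccccc1` gives 91.2 ug/mL in an ADME assay on RD cells (Homo sapiens) for cytotoxicity, read by MTT assay, with a stated time of 3 days; on this read-out lower numbers stand for higher toxicity in this test and higher numbers for lower toxicity in this test. Compound 2 `CC[C@@H](CCn1cncn1)c1ccc(F)cc1` gives 91.6 ug/mL in this assay, and compound 3 `CC[C@@H](CCn1cncn1)c1ccc(OC)cc1` gives 115 ug/mL in this assay. Compound 2 thus holds the second highest of the three numbers; its nearest neighbour is compound 1 and its furthest is compound 3, both within the scatter. The measured steps are a 1.0-fold higher number from compound 1 to compound 2 (0.00 log units; within the scatter), a 1.3-fold higher number from compound 1 to compound 3 (0.10 log units; within the scatter) and a 1.3-fold higher number from compound 2 to compound 3 (0.10 log units; within the scatter); all three change the aromatic carbon and none crosses the scatter. Compound 4 `CCC[C@@H](CCn1cncn1)c1ccc(F)cc1` differs from compound 2 by methyl in place of hydrogen on a saturated chain carbon, three bonds along the chain from an aromatic carbon. Among the measured compounds shown here, no measured step touches the chain, so the aromatic steps bear on this change only by showing that every small change so far left this assay flat. On that basis a step of a 1.0-fold lower number from compound 2 to compound 4 (0.01 log units; within the scatter) is expected, with no movement beyond the scatter. Compound 4 is therefore estimated at 90 ug/mL in this assay, within 45 ug/mL to 180 ug/mL.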

Compound 4, half-maximal cytotoxic concentration: 56.9 ug/mL
Estimate against measurement, compound 4: 1.6-fold (0.20 log units) above; the range from low to high includes it.
By their numbers in this assay, from the lowest: compounds 4, 1, 2 and 3 (each within the scatter of the next, the first and the last beyond it).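

Ethyl to propyl gives the first reading on the chain, and in this assay it is a 1.6-fold lower number from compound 2 to compound 4 (0.21 log units; within the scatter). Methyl in place of hydrogen on this saturated chain carbon, three bonds along the chain from an aromatic carbon, therefore joins the changes at the aromatic carbon as a step that cannot be told from repeat scatter. The flat picture, until now known only from the aromatic carbon, thus extends to one chain change on the fluoro compound, though a single step cannot fix a trend along the chain.

The compounds shown leave open whether a butyl chain or a chain ending in an amine or a carboxylic acid would move the number beyond the scatter. They also leave open whether ethyl to propyl reads the same with methoxy or hydrogen on the aromatic carbon. No supporting measurement shown here accounts for this step.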